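This account rests on a few compounds, and the source may have more. Where it says the series, first, only, none or still open, it means among the compounds named here.

Measured so far:
- Compound 1, `CCCOC(=O)CSc1nc2cc(-n3nc(C(C)(C)C)sc3=O)c(F)cc2s1`: in an assay on isolated protein for inhibition of protoporphyrinogen oxidase (Homo sapiens), read by capillary electrophoresis (on this read-out lower numbers stand for stronger inhibition and higher numbers for weaker inhibition), compound 1 gives 1310 nM
- Compound 2, `CCOC(=O)CSc1nc2cc(-n3nc(C(C)(C)C)sc3=O)c(Cl)cc2s1`: in this assay compound 2 gives 5820 nM

Both compounds share one core and differ in two places at once, a halogen on the core and the length of the ester chain, so no single step can be read from their numbers. Compound 2 stands at the higher of the two numbers in this assay, the weaker inhibition of the pair, and its distance from compound 1 is beyond the usual scatter.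

Compound 3, `C#CCSc1nc2cc(-n3nc(C(C)(C)C)sc3=O)c(Cl)cc2s1`, keeps the halogen of compound 2 and changes only the chain on the sulfur: ethynyl in place of ethoxycarbonyl on a saturated chain carbon bound to a sulfur. Among the compounds with values here, no measured pair shows this change, so its effect is open. The expectation is that compound 3 lands at a somewhat lower number than compound 2, a step of moderate size, a 2.3-fold lower number from compound 2 to compound 3 (0.37 log units; beyond the scatter), though a result within the scatter of compound 2 cannot be ruled out. The estimate for compound 3 in this assay is 2500 nM, expected to fall between 500 nM and 12000 nM.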

Compound 3, inhibition constant: 21400 nM
Compound 3: middle estimate off by 8.6-fold (0.93 log units), on the low side, outside the stated range (above it).
By their numbers in this assay, from the lowest: compound 1; then compound 2; then compound 3.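

In this assay, within the data shown here, the chain on the sulfur gives the first change that can be read on its own. The halogen on the core stays the same: ethynyl in place of ethoxycarbonyl on a saturated chain carbon bound to a sulfur gives a 3.7-fold higher number from compound 2 to compound 3 (0.57 log units; beyond the scatter). This shows that the position is not indifferent to what the chain carries, and that, on this one pair, the (ethoxycarbonyl)methyl group goes with stronger inhibition than the smaller propargyl group, which has no hydrogen-bond acceptors where the ester has two. Nothing measured here says why the number rises with this change.

The compounds shown do not separate the loss of the ester from the shortening of the chain, so a carboxylic acid, an amide or a plain propyl chain on the same sulfur would each be a further test of what this position responds to. Steps involving compound 1 cannot be read, since it differs from the others in more than one place, so whether this change would have the same effect with fluorine on the core also stays open.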